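A few compounds are considered here, and "the series" means these few. Any claim that something is new, unique, unknown or untested is made for them only; others in the source may bear on it.

Values in an ADME assay on HEK293 cells (Homo sapiens) for cytotoxicity; on this read-out lower numbers stand for stronger inhibition and higher numbers for weaker inhibition:

- Compound 1 `CCCCCCCCCCCCCCNC(=O)[C@H](CO)/N=C/c1cccc(C)c1`: 51100 nM
- Compound 2 `CCCCCCCCCCCCCCNC(=O)[C@H](CO)/N=C/c1ccccc1OC`: 79200 nM
- Compound 3 `CCCCCCCCCCCCCCNC(=O)[C@H](CO)/N=C/c1ccccc1Cl`: 94900 nM

Compound 3 cannot be separated from the other two on these numbers. The steps to it are a 1.2-fold higher number from compound 2 to compound 3 (0.08 log units; within the scatter) and a 1.9-fold higher number from compound 1 to compound 3 (0.27 log units; within the scatter). Compound 4 `CCCCCCCCCCCCCCNC(=O)[C@H](CO)/N=C/c1ccc(Cl)cc1` has the same atoms joined differently: 4-chlorophenyl in place of 2-chlorophenyl on a carbon with a double bond to nitrogen, with 4-chlorophenyl in place of 2-chlorophenyl on a carbon with a double bond to nitrogen. Going by the values given here, no measured pair shows this exact change. The closest evidence is the other changes of the group on that carbon, such as a 1.5-fold higher number from compound 1 to compound 2 (0.19 log units; within the scatter), and every measured step stayed within the scatter. No step beyond the scatter is therefore expected in this assay. The estimated change is a 1.3-fold lower number from compound 3 to compound 4 (0.10 log units; within the scatter). Compound 4 is expected at 75000 nM, with an estimated range of 38000 nM to 150000 nM.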

Compound 4, half-maximal inhibitory concentration: 77700 nM
For compound 4 the middle estimate is 1.0-fold (0.02 log units) below the measured one; measured number inside the range.
By their numbers in this assay, from the lowest: compounds 1, 4, 2 and 3 (each within the scatter of the next).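

In this assay the swap of 2-chlorophenyl for 4-chlorophenyl on the carbon with a double bond to nitrogen gives a 1.2-fold lower number from compound 3 to compound 4 (0.09 log units; within the scatter) and so does not separate the two placements of the chlorine. Going by these compounds alone, compound 4 also stays level with the other two, with a 1.0-fold lower number from compound 2 to compound 4 (0.01 log units; within the scatter) and a 1.5-fold higher number from compound 1 to compound 4 (0.18 log units; within the scatter), so no step at this position has yet left the scatter. Nothing available bears on this result. The compounds shown leave open whether an amine or a carboxylic acid on the aromatic ring, or a shorter chain in place of the long one, would move the number beyond the scatter.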